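Ring nitrogen substitution: from hydrogen to 4-nitrophenyl

This account rests on a few compounds, and the source may have more. Where it says the series, first, only, none or still open, it means among the compounds named here.

Two members of the series carry measurements. Compound 1 `O=CN1N=C(c2ccc(F)cc2)CC1c1cn(-c2ccccc2)nc1-c1ccc(Cl)c(Cl)c1` bears a formyl group on the amine nitrogen in the ring; in a functional assay on the whole organism (strain Wistar) for inhibition, with Rattus norvegicus as the target, read by paw edema, with stated times of 30 min and 60 min, at a dose of 50 mg/kg by the oral route (a higher number here means more inhibition at the dose given (going by the name of the read-out), a lower number less inhibition), compound 1 gives 56.5%. Compound 2 `Fc1ccc(C2=NNC(c3cn(-c4ccccc4)nc3-c3ccc(Cl)c(Cl)c3)C2)cc1` has a hydrogen on that nitrogen instead, and in this assay compound 2 gives 40.5%. Going by the values given here, the single step between the two is a number 16 percentage points lower from compound 1 to compound 2 (beyond the scatter), so compound 2 stands lowest of the two numbers, with compound 1 the only neighbour.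

Compound 3 `O=[N+]([O-])c1ccc(N2N=C(c3ccc(F)cc3)CC2c2cn(-c3ccccc3)nc2-c2ccc(Cl)c(Cl)c2)cc1` has not been measured. It differs from compound 2 in one place: 4-nitrophenyl in place of hydrogen on an amine nitrogen in a ring.

Among the compounds with values here, only one measured step touches the same nitrogen, and it shows that removing the formyl group from compound 1 lowers inhibition by a number 16 percentage points lower from compound 1 to compound 2 (beyond the scatter). Within the data shown here, putting a group back onto that nitrogen is therefore expected to move this assay upward, by a step of roughly that size; a 4-nitrophenyl group is, however, not formyl, and no second step calibrates such a large group, so the range is set wide.

On this basis compound 3 is estimated at 55%, with a range of 40% to 70%. The step this estimate implies is a number 14.5 percentage points higher from compound 2 to compound 3 (beyond the scatter).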

Compound 3, a percentage reported as inhibition, in the whole organism at one dose (the size of the read-out at that dose, not a potency): 60.3%
For compound 3 the middle estimate is 5.3 percentage points below the measured one, and the stated range covers the measured number.
By their numbers in this assay, from the lowest: compound 2; then compounds 1 and 3 (each within the scatter of the next).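

Substitution on the amine nitrogen in the ring is now supported by two different groups: in this assay, 4-nitrophenyl in place of hydrogen gives a number 19.8 percentage points higher from compound 2 to compound 3 (beyond the scatter), in the same direction as the formyl comparison, where removing the group gives a number 16 percentage points lower from compound 1 to compound 2 (beyond the scatter). Exchanging one substituent for the other gives a number 3.8 percentage points higher from compound 1 to compound 3 (within the scatter), so this assay does not separate 4-nitrophenyl from formyl, and this nitrogen accepts an aromatic ring as well as a small carbonyl group without loss of the reading seen with formyl. Nothing available on these compounds accounts for the gain over hydrogen at this nitrogen.

On these data alone, whether the aromatic ring alone is enough, or the nitro group contributes, remains open, and an unsubstituted phenyl, a 4-methoxyphenyl or a 4-aminophenyl on the same nitrogen would address that question. Also open, as far as these compounds go, is whether the effect extends to other acyl groups such as acetyl, and, with readings at a single dose only, whether compound 1 and compound 3 would still match across a range of doses.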